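Compound 1 to compound 4: trifluoromethyl for hydroxyamino

The source may hold more compounds than are shown below. What is called first, only, known or untested is meant among the compounds shown, and "the series" means these compounds.

For the measured compounds named here, in a functional assay on NCI-H661 cells (Homo sapiens) for antiproliferative activity, read by MTT assay, with a stated time of 72 h (a lower number here means a stronger inhibitor, a higher number a weaker inhibitor), compound 1 (`Cc1ccc(-c2noc(CCCCCCC(=O)NO)n2)cc1`) gives 15800 nM and sits within the scatter of compound 2 (`COc1ccc(-c2noc(CCCCCCC(=O)NO)n2)cc1`) at 20400 nM on the numbers so far. Compound 3 (`O=C(CCCCCCc1nc(-c2cccnc2)no1)NO`) gives 6020 nM and lies beyond the scatter of compound 1, so compound 1 stands in the upper part of this small set.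

The open case is compound 4 (`Cc1ccc(-c2noc(CCCCCCC(=O)C(F)(F)F)n2)cc1`). Its change from compound 1 is trifluoromethyl in place of hydroxyamino on a carbonyl carbon whose other neighbour is a saturated chain carbon, counted as trifluoromethyl in place of hydroxyamino on a carbonyl carbon with the rest of the structure unchanged.

Both measured steps sit on an aromatic carbon. Methoxy in place of methyl gives a 1.3-fold higher number from compound 1 to compound 2 (0.11 log units; within the scatter) and pyridin-3-yl in place of 4-methylphenyl gives a 2.6-fold lower number from compound 1 to compound 3 (0.42 log units; beyond the scatter) and so neither speaks directly to a change on the carbonyl carbon. Going by the values given here, the series holds no measured step at that place, which leaves the expectation resting on the structural change alone and makes it uncertain. A move towards a higher number in this assay is expected, of modest size but with a wide margin. The expected step is a 2.5-fold higher number from compound 1 to compound 4 (0.40 log units; beyond the scatter) and remains a rough estimate. Compound 4 is estimated at 40000 nM within a range from 12000 nM to 120000 nM as the expected result.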

Compound 4, half-maximal inhibitory concentration: 18700 nM
The estimate for compound 4 lay 2.1-fold (0.33 log units) above the measured number; low and high end bracket the measured number.
By their numbers in this assay, from the lowest: compound 3; then compounds 1, 4 and 2 (each within the scatter of the next).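

In this assay, for the compounds shown here, the exchange of hydroxyamino for trifluoromethyl on a carbonyl carbon gives a 1.2-fold higher number from compound 1 to compound 4 (0.07 log units; within the scatter), the first measured step at this place, since the earlier steps both sat on an aromatic carbon. The number therefore stays inside the scatter when the hydroxycarbamoyl group gives way to (trifluoromethyl)carbonyl, even though the hydroxyamino group counted 2 hydrogen-bond donors and 1 hydrogen-bond acceptor and the trifluoromethyl group counts none, so in this pair those counts do not track the antiproliferative read-out. No measurement on the series gives a reason for this result.

This single pair cannot show whether the same exchange gives a comparable step on compound 3, which carries pyridin-3-yl and stands beyond the scatter of compound 1. It also leaves open how a carboxylic acid or a primary amide would read on the same carbonyl position, and whether a longer chain in place of the saturated chain would keep hydroxyamino and trifluoromethyl as close together in this cell line.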